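This account rests on a few compounds, and the source may have more. Where it says the series, first, only, none or still open, it means among the compounds named here.

Going by the values given here, compound 3 `Brc1ccc(CSc2nnc(-c3ccncc3)n2-c2ccccc2)cc1` stands second highest of the three numbers so far in a functional assay on MCF7 cells (Homo sapiens) for inhibition, read by MTT assay, with a stated time of 48 h; on this read-out higher numbers stand for weaker inhibition and lower numbers for stronger inhibition. Its nearest neighbour is compound 1 `Brc1cccc(CSc2nnc(-c3ccncc3)n2-c2ccccc2)c1`, which gives 10000 nM where compound 3 gives 12600 nM; compound 2 `Fc1ccc(CSc2nnc(-c3ccncc3)n2-c2ccccc2)cc1` gives 21100 nM and lies furthest from it. The step of a 1.3-fold higher number from compound 1 to compound 3 (0.10 log units; within the scatter) lies within the scatter, as does a 1.7-fold lower number from compound 2 to compound 3 (0.22 log units; within the scatter), while a 2.1-fold higher number from compound 1 to compound 2 (0.32 log units; beyond the scatter) is a modest move beyond it.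

Compound 4 `O=[N+]([O-])c1cccc(CSc2nnc(-c3ccncc3)n2-c2ccccc2)c1` differs from compound 3 in one place: 3-nitrophenyl in place of 4-bromophenyl on a saturated chain carbon bound to a sulfur. Among the compounds with values here, none of the measured steps exchanges a halogen for a nitro group, so no direct precedent exists. Within the data shown here, the only step that touches the same ring position, a 1.3-fold higher number from compound 1 to compound 3 (0.10 log units; within the scatter), moved the number within the scatter, and the largest step seen anywhere, a 2.1-fold higher number from compound 1 to compound 2 (0.32 log units; beyond the scatter), was itself modest. All three measured numbers sit in a narrow band, which gives little ground to expect a large move in this assay in either direction.

Compound 4 is therefore expected to stay close to compound 3, with an estimated step of a 1.1-fold lower number from compound 3 to compound 4 (0.06 log units; within the scatter). The estimate for compound 4 in this assay is 11000 nM, within a range of 4500 nM to 30000 nM.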

Compound 4, half-maximal inhibitory concentration: 18300 nM
Compound 4: the middle estimate sits 1.7-fold (0.22 log units) below what was measured; the measured number falls inside the stated range.
By their numbers in this assay, from the lowest: compounds 1, 3, 4 and 2 (each within the scatter of the next, the first and the last beyond it).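

In this assay, the step of a 1.8-fold higher number from compound 1 to compound 4 (0.26 log units; within the scatter) exchanges a halogen for a nitro group at an unchanged ring position and stays within the scatter, as do a 1.5-fold higher number from compound 3 to compound 4 (0.16 log units; within the scatter) and a 1.2-fold lower number from compound 2 to compound 4 (0.06 log units; within the scatter). This place on a saturated chain carbon bound to a sulfur therefore accepts 3-nitrophenyl, which carries hydrogen-bond acceptors where 4-bromophenyl has none, without a step beyond the scatter from any of the three earlier compounds. Going by these compounds alone, compound 4 also lies within the scatter of both compound 1 and compound 2, so the only step beyond the scatter remains a 2.1-fold higher number from compound 1 to compound 2 (0.32 log units; beyond the scatter), and no measurement of another kind is at hand to explain these small differences.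

The compounds shown leave open whether a group of a different kind on this ring, such as an amine or a carboxylic acid, would move the number beyond the scatter. They also leave open what a longer chain between the ring and the sulfur would do, and whether 4-nitrophenyl would match 3-nitrophenyl at this place.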